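The compounds below may be only part of what the source reports. "The series", "measured", "known", "first", "only" and "open" are said of these compounds alone.

Working notes on the series, read in a functional assay on NCI-H460 cells (Homo sapiens) for cytotoxicity, read by MTT assay, with a stated time of 72 h; on this read-out lower numbers stand for stronger inhibition and higher numbers for weaker inhibition: compound 1 `CC(C)c1[nH]cnc1/C=c1\[nH]c(=O)/c(=C/c2cccc(Oc3ccc(F)cc3)c2)[nH]c1=O` gives 8.8 nM, compound 2 `O=c1[nH]/c(=C\c2c[nH]cn2)c(=O)[nH]/c1=C\c1cccc(Oc2ccc(F)cc2)c1` gives 479 nM, and compound 3 `O=c1[nH]/c(=C\c2ccc(CO)o2)c(=O)[nH]/c1=C\c1cccc(Oc2ccc(F)cc2)c1` gives 41.5 nM, the middle of the three numbers. Compound 4 `COCc1ccc(/C=c2\[nH]c(=O)/c(=C/c3cccc(Oc4ccc(F)cc4)c3)[nH]c2=O)o1` differs from compound 3 by methyl in place of hydrogen on an oxygen on a saturated carbon, hydroxymethyl to methoxymethyl. Among the compounds with values here, no measured step alters this hydroxy directly. The nearest evidence swaps the whole group: a 12-fold lower number from compound 2 to compound 3 (1.06 log units; beyond the scatter) and a 4.7-fold higher number from compound 1 to compound 3 (0.67 log units; beyond the scatter). A single substituent can also matter, as a 54-fold higher number from compound 1 to compound 2 (1.74 log units; beyond the scatter) shows, so the range stays wide. Only a small step of uncertain direction, within the scatter, is expected in this assay. The expected step is a 1.2-fold lower number from compound 3 to compound 4 (0.07 log units; within the scatter). Compound 4 is estimated at 35 nM, with an expected range from 12 nM to 100 nM.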

Compound 4, half-maximal inhibitory concentration: 14 nM
Estimate against measurement, compound 4: 2.5-fold (0.40 log units) above; measured number inside the range.
By their numbers in this assay, from the lowest: compounds 1 and 4 (each within the scatter of the next); then compound 3; then compound 2.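

Putting methyl on this oxygen is tolerated, and the hydroxy hydrogen is not needed to hold the number here (a 3.0-fold lower number from compound 3 to compound 4 (0.47 log units; beyond the scatter)). With methoxymethyl in place, the 5-(methoxymethyl)furan-2-yl compound stands far from the bare 1H-imidazol-4-yl compound (a 34-fold lower number from compound 2 to compound 4 (1.53 log units; beyond the scatter)) and level with the 5-isopropyl-1H-imidazol-4-yl compound (a 1.6-fold higher number from compound 1 to compound 4 (0.20 log units; within the scatter)), a step within the scatter. Nothing on hand bears on why the methyl shifts the number.

From the compounds shown here alone, whether an ethyl or longer chain on this oxygen would hold the number remains open. So does the outcome of an amine in place of the methoxy.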